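The source may hold more compounds than are shown below. What is called first, only, known or untested is meant among the compounds shown, and "the series" means these compounds.

Of the compounds shown here, three with the same core have so far been tested in a functional assay on COR-L23 cells (Homo sapiens) for antiproliferative activity, read by CellTiter-Glo, with a stated time of 4 days; a lower number here means a stronger inhibitor, a higher number a weaker inhibitor. Compound 1 `CCC(=O)N[C@@H](C)c1ccc(NC(=O)[C@H]2C[C@@H]2c2cccnc2)cc1` gives 22 nM, compound 2 `C[C@H](NC(=O)[C@@H]1CCCN1C)c1ccc(NC(=O)[C@H]2C[C@@H]2c2cccnc2)cc1` gives 11 nM, and compound 3 `C[C@H](NC(=O)c1ccc(C#N)cc1)c1ccc(NC(=O)[C@H]2C[C@@H]2c2cccnc2)cc1` gives 19 nM. Compound 3 thus lies within the scatter of both others, so these numbers set no order among the three.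

Compound 4 `C[C@H](NC(=O)c1ccccn1)c1ccc(NC(=O)[C@H]2C[C@@H]2c2cccnc2)cc1` has pyridin-2-yl in place of 4-cyanophenyl on a carbonyl carbon. The measured steps that bear on this change altered the group at the same place: a 2.0-fold lower number from compound 1 to compound 2 (0.30 log units; within the scatter), a 1.2-fold lower number from compound 1 to compound 3 (0.06 log units; within the scatter) and a 1.7-fold higher number from compound 2 to compound 3 (0.24 log units; within the scatter). All three stay within the scatter, even though ethyl, 1-methylpyrrolidin-2-yl and 4-cyanophenyl are quite different groups. For the measured compounds named here, no measured compound carries pyridin-2-yl there, so this expectation rests on only three compounds. No step beyond the scatter is therefore expected in this assay. The expected step is a 1.1-fold lower number from compound 3 to compound 4 (0.02 log units; within the scatter). Compound 4 is estimated at 18 nM, with an expected range from 8 nM to 40 nM.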

Compound 4, half-maximal inhibitory concentration: 46 nM
For compound 4 the middle estimate is 2.6-fold (0.41 log units) below the measured one; measured number above the stated range.
By their numbers in this assay, from the lowest: compounds 2, 3 and 1 (each within the scatter of the next); then compound 4.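

In this assay, this place on the carbonyl carbon turns out not to accept every group alike: pyridin-2-yl gives a 2.4-fold higher number from compound 3 to compound 4 (0.38 log units; beyond the scatter), a 4.2-fold higher number from compound 2 to compound 4 (0.62 log units; beyond the scatter) and a 2.1-fold higher number from compound 1 to compound 4 (0.32 log units; beyond the scatter). Compound 4 is therefore the weakest of the four, although ethyl, 1-methylpyrrolidin-2-yl and 4-cyanophenyl could not be told apart, so neither the size of the group nor the presence of a ring alone sorts these compounds. No measurement shown accounts for this difference.

The change from compound 3 to compound 4 removes the nitrile and also puts a nitrogen into the ring, and these compounds cannot separate the two. As far as these compounds go, whether plain phenyl, with neither feature, would match compound 3 or compound 4 remains open, as does the result for a longer alkyl chain.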